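The source may hold more compounds than are shown below. What is called first, only, known or untested is meant among the compounds shown, and "the series" means these compounds.

Compound 1, `COc1cc(/C=C/C(=O)c2cccc(NC(=O)c3cccs3)c2)ccc1O`, gives 71% in a functional assay on HUVEC cells (Homo sapiens) for inhibition, tested at 2.5 ug/mL; on this read-out higher numbers stand for a stronger effect at the one concentration tested and lower numbers for a weaker effect.
Compound 2, `COc1cc(/C=C/C(=O)c2cccc(NC(=O)c3cc(Cl)cc(Cl)c3)c2)ccc1O`, gives 15% in this assay.
Compound 3, `COc1cc(/C=C/C(=O)c2cccc(NC(=O)c3ccco3)c2)ccc1O`, gives 61% in this assay.

Compound 3 stands second highest of these three numbers. Its nearest neighbour is compound 1: the step of a number 10 percentage points lower from compound 1 to compound 3 (within the scatter) stays within the scatter, so the two cannot be told apart. Its furthest neighbour is compound 2, from which the step of a number 46 percentage points higher from compound 2 to compound 3 (beyond the scatter) is large.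

Compound 4, `COc1cc(/C=C/C(=O)c2cccc(NC(=O)c3ccc(Cl)cc3Cl)c2)ccc1O`, differs from compound 3 in one place: 2,4-dichlorophenyl in place of furan-2-yl on a carbonyl carbon.

Going by the values given here, two measured steps bear on this change. Both replace a five-membered aromatic ring by a dichlorophenyl ring on the carbonyl carbon, or the reverse: a number 56 percentage points lower from compound 1 to compound 2 (beyond the scatter) and a number 46 percentage points higher from compound 2 to compound 3 (beyond the scatter). Each was large, and in each case the dichlorophenyl compound was the weaker one. The change to compound 4 goes the same way, so a large drop in this assay is expected, roughly a number 39 percentage points lower from compound 3 to compound 4 (beyond the scatter).

Compound 4 is therefore estimated at 22%, with a range from 5% to 45%.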

Compound 4, a percentage reported as inhibition, at one concentration (the size of the read-out at that concentration, not a potency): 29%
Compound 4: middle estimate off by 7 percentage points, on the low side; measured number inside the range.
By their numbers in this assay, from the lowest: compound 2; then compound 4; then compounds 3 and 1 (each within the scatter of the next).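

Compound 4 shows that the lower numbers in this assay are not confined to the 3,5-dichlorophenyl group of compound 2: a second dichlorophenyl pattern on this carbonyl carbon also gives a large step away from each five-membered ring, namely a number 32 percentage points lower from compound 3 to compound 4 (beyond the scatter) and a number 42 percentage points lower from compound 1 to compound 4 (beyond the scatter). It also shows that the two dichlorophenyl groups are not interchangeable, with a number 14 percentage points higher from compound 2 to compound 4 (beyond the scatter), so the arrangement of the two chlorines on the ring goes with a modest change in the number. Nothing measured here explains either difference.

The part played by the six-membered ring itself and the part played by its chlorines remain unseparated. An unsubstituted phenyl ring or a 4-chlorophenyl ring on this carbonyl carbon could help to tell them apart.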